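The source may report more compounds than this note shows. Statements on the series, on what has been measured and on what is new or still open speak of the compounds shown alone.

Compound 1 (`CCN(C)CCCOc1ccc2cc(NC(=O)c3ccc(O)c(CC=C(C)C)c3)c(=O)oc2c1C`) gives (2190 nM)
Compound 2 (`CCCNCCCOc1ccc2cc(NC(=O)c3ccc(O)c(CC=C(C)C)c3)c(=O)oc2c1C`) gives (980 nM)

Among the measured compounds shown here, in a functional assay on MCF7 cells (Homo sapiens) for antiproliferative activity (a higher number here means a weaker inhibitor, a lower number a stronger inhibitor), compound 2 has the lower of the two numbers measured so far (980 nM), and compound 1 stands higher (2190 nM). Compound 3 (`CC(C)=CCc1cc(C(=O)Nc2cc3ccc(OCCCN(C)C(C)C)c(C)c3oc2=O)ccc1O`) has not yet been measured. It differs from compound 2 by a single change (isopropyl(methyl)amino in place of propylamino on a saturated chain carbon, three bonds along the chain from an oxygen on an aromatic ring): isopropyl(methyl)amino in place of propylamino on a saturated chain carbon, three bonds along the chain from an oxygen on an aromatic ring.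

For the measured compounds named here, only one measured step bears on this change. The step of a 2.2-fold lower number from compound 1 to compound 2 (0.35 log units; beyond the scatter) exchanged ethyl(methyl)amino for propylamino at the same place, and it was modest. Isopropyl(methyl)amino again carries a methyl group on the amine, as ethyl(methyl)amino does in compound 1 (2190 nM), so a step of similar modest size towards a higher number is expected in this assay. As far as these compounds go, this rests on one step alone, and isopropyl itself is untested here. The expected step is a 1.9-fold higher number from compound 2 to compound 3 (0.29 log units; within the scatter), an estimate with wide uncertainty. Compound 3 is estimated at 1900 nM, within an expected range from 800 nM to 4500 nM.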

Compound 3, half-maximal inhibitory concentration: 1050 nM
Estimate against measurement, compound 3: 1.8-fold (0.26 log units) above, and the stated range covers the measured number.
By their numbers in this assay, from the lowest: compounds 2 and 3 (each within the scatter of the next); then compound 1.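

Moving from propylamino to isopropyl(methyl)amino in this assay gives a 1.1-fold higher number from compound 2 to compound 3 (0.03 log units; within the scatter), so at this place on the saturated chain carbon, the amine can lose its hydrogen-bond donor and gain a methyl group without a separable change in the number. The methyl group on the amine therefore does not by itself set compound 1 apart, since compound 3 carries one too, and a single further methyl on the saturated chain carbon bound to the amine nitrogen gives a 2.1-fold lower number from compound 1 to compound 3 (0.32 log units; beyond the scatter), a modest step that is comparable to the one seen with propylamino in compound 2. Nothing available explains why these three amines stand as they do.

The compounds shown leave open how a ring amine such as piperidine or morpholine, or a primary amine, would stand at this place. They also leave open whether a longer chain between the aromatic oxygen and the amine would keep these small differences or change them.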